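This account rests on a few compounds, and the source may have more. Where it says the series, first, only, none or still open, it means among the compounds named here.

- Compound 1 `Cn1ncc2c(=O)n(-c3ccccc3)c(SCc3cccc(F)c3)cc21` gives 178000 nM 
- Compound 2 `O=c1c2cn(C3COC3)nc2nc(SCc2cccc(F)c2)n1-c1ccccc1` gives 5000 nM 
- Compound 3 `Cn1ncc2c(=O)n(-c3ccccc3)c(SCc3cccc(F)c3)nc21` gives < 700 nM as a limit

All three were tested in a physicochemical assay for solubility, using the shake flask method, in phosphate buffer, with a stated time of 24 h, at pH 7.4 (a higher number here means a more soluble compound, a lower number a less soluble compound), and, of the two true numbers, compound 2 holds the lower at 5000 nM while compound 1 stands higher at 178000 nM in the same measurement. The gap between these two numbers lies beyond the scatter. The value of compound 3 is a limit.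

Compound 4 `CC(Sc1nc2nn(C3COC3)cc2c(=O)n1-c1ccccc1)c1ccccc1` is not yet measured. It differs from compound 2 by 1-phenylethyl in place of 3-fluorobenzyl on a sulfur with 1-phenylethyl in place of 3-fluorobenzyl on a sulfur. Within the data shown here, no measured pair shows this exchange, so the expectation rests on compound 2 at 5000 nM alone. A step of a 1.3-fold lower number from compound 2 to compound 4 (0.10 log units; within the scatter) is expected in this assay and would stay within the scatter. Compound 4 is estimated at 4000 nM with an expected range from 1200 nM to 13000 nM in this measurement.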

Compound 4, solubility: 26000 nM
Beside the measured number, compound 4's estimate is 6.5-fold (0.81 log units) below it; measured number outside the range, above it.
By their numbers in this assay, from the lowest: compound 2; then compound 4; then compound 1. At a limit, below all of these: compound 3.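

In this assay, among these compounds, 1-phenylethyl in place of 3-fluorobenzyl on a sulfur gives a 5.2-fold higher number from compound 2 to compound 4 (0.72 log units; beyond the scatter), so this position, which carries 3-fluorobenzyl in all the earlier compounds, does move the read-out. Both groups hold 8 heavy atoms and one six-membered aromatic ring of carbon only, so the step arises even though these counts stay alike. Nothing measured here gives a cause for this step.

The compounds shown leave open whether the fluorine that leaves or the carbon that enters carries the step. Also open, going by these compounds, is how an amine or a carboxylic acid in place of 1-phenylethyl on a sulfur would read in this assay.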